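The source may report more compounds than this note shows. Statements on the series, on what has been measured and on what is new or still open speak of the compounds shown alone.

Compound 1, `CC(C)CN(Cc1ccccc1-c1ccccc1)[C@@H]1C[C@@H](CNC(=O)/C=C/c2ccc(/C=C3\SC(=O)NC3=O)cc2)N(C(=O)c2ccccc2C(=O)c2ccc(F)cc2)C1`: 52 nM
Compound 2, `CC(C)Cc1cccc(Br)c1O[C@@H]1C[C@@H](CNC(=O)c2ccc(/C=C3\SC(=O)NC3=O)cc2)N(C(=O)c2ccccc2C(=O)c2ccc(F)cc2)C1`: 300 nM

Among the measured compounds shown here, in a functional assay on THP-1 cells (Homo sapiens) for inhibition (a higher number here means a weaker inhibitor, a lower number a stronger inhibitor), compound 2 gives 300 nM, the higher of the two numbers measured so far, while compound 1 gives 52 nM, a gap beyond the usual scatter. Compound 3, `CC(C)Cc1cccc(-c2ccccc2C(C)C)c1O[C@@H]1C[C@@H](CNC(=O)c2ccc(/C=C3\SC(=O)NC3=O)cc2)N(C(=O)c2ccccc2C(=O)c2ccc(F)cc2)C1`, differs from compound 2 in one place: 2-isopropylphenyl in place of bromo on an aromatic carbon. For the measured compounds named here, no measured pair shows this same change, so nothing here tells how far it moves the number. The step is expected to be small, toward a lower number, and not clearly beyond the scatter: a 1.5-fold lower number from compound 2 to compound 3 (0.18 log units; within the scatter). Compound 3 is therefore expected to give about 200 nM, most likely between 60 nM and 700 nM.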

Compound 3, half-maximal inhibitory concentration: 92 nM
Compound 3: middle estimate off by 2.2-fold (0.34 log units), on the high side, and the stated range covers the measured number.
By their numbers in this assay, from the lowest: compounds 1 and 3 (each within the scatter of the next); then compound 2.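

In this assay, the aromatic carbon that held the bromo group also tolerates 2-isopropylphenyl, a group of 9 heavy atoms with its own six-membered aromatic ring, and the number falls (a 3.3-fold lower number from compound 2 to compound 3 (0.51 log units; beyond the scatter)). This position is therefore not restricted to a single atom, at least for this replacement. No measurement here explains the change.

Going by these compounds, it remains open whether the ring or its isopropyl group accounts for the step. How an unsubstituted phenyl or an amine would behave at this position is also unknown.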